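Moving the Alkyl Group on the Furan Ring

A few compounds are considered here, and "the series" means these few. Any claim that something is new, unique, unknown or untested is made for them only; others in the source may bear on it.

Measured compounds:
compound 1 `CC[C@@H](Nc1c(Nc2cccc(C(=O)N(C)C)c2O)c(=O)c1=O)c1cc(C)cs1` gives 24 nM
compound 2 `CCc1ccoc1[C@@H](CC)Nc1c(Nc2cccc(C(=O)N(C)C)c2O)c(=O)c1=O` gives 379 nM

Both compounds were tested in an assay on CHO cells for displacement of a labelled ligand from C-X-C chemokine receptor type 1 (Homo sapiens); on this read-out lower numbers stand for stronger inhibition and higher numbers for weaker inhibition. Compound 2 holds the highest of the two numbers; its nearest neighbour is compound 1, and the step of a 16-fold higher number from compound 1 to compound 2 (1.20 log units; beyond the scatter) separates them, well beyond the scatter.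

Compound 3 `CCC(C)c1coc([C@@H](CC)Nc2c(Nc3cccc(C(=O)N(C)C)c3O)c(=O)c2=O)c1` has not yet been measured. It keeps the furan ring of compound 2 but changes the alkyl group and its place on that ring: 4-(sec-butyl)furan-2-yl in place of 3-ethylfuran-2-yl on a saturated chain carbon bound to a nitrogen on an aromatic ring and a saturated chain carbon.

Going by the values given here, only one measured step bears on this change, a 16-fold higher number from compound 1 to compound 2 (1.20 log units; beyond the scatter), and it describes a different swap, an exchange of the whole ring together with its substituent. Among the compounds with values here, no measured pair shows what moving an alkyl group on the furan ring alone does. The substituent name of compound 3, 4-(sec-butyl)furan-2-yl, shares its numbering pattern with the 4-methylthiophen-2-yl of compound 1, the compound with the lower number, so a step back toward that value is expected, but a modest one, given the lack of direct evidence.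

Compound 3 is therefore estimated at 120 nM, within 30 nM to 500 nM, a step of a 3.2-fold lower number from compound 2 to compound 3 (0.50 log units; beyond the scatter) in this assay.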

Compound 3, inhibition constant: 7.6 nM
Compound 3: middle estimate off by 16-fold (1.20 log units), on the high side; measured number below the stated range.
By their numbers in this assay, from the lowest: compound 3; then compound 1; then compound 2.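

In this assay a furan ring on this saturated chain carbon can go with a low number: keeping the ring type but exchanging 3-ethylfuran-2-yl for 4-(sec-butyl)furan-2-yl gives a 50-fold lower number from compound 2 to compound 3 (1.70 log units; beyond the scatter), so the high number of compound 2 does not follow from the furan ring alone. A thiophene ring is not needed for a low number here either, since the exchange of 4-methylthiophen-2-yl for 4-(sec-butyl)furan-2-yl gives a 3.2-fold lower number from compound 1 to compound 3 (0.50 log units; beyond the scatter). Nothing measured here explains why these exchanges move the number as they do.

As far as these compounds go, the step from compound 2 to compound 3 alters the alkyl group and its place on the ring at once, so the share of each stays unknown; 4-ethylfuran-2-yl and 3-(sec-butyl)furan-2-yl would be the two compounds that separate them. From the compounds shown here alone, it also stays open whether a tert-butyl group or a longer chain in place of the sec-butyl group would lower the number further, and whether 4-(sec-butyl)thiophen-2-yl would match compound 3.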